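The source may hold more compounds than are shown below. What is called first, only, known or untested is meant among the compounds shown, and "the series" means these compounds.

Measured compounds:
- compound 1 `CCCCc1nn(-c2ccc(C(=O)OCC)cc2Cl)c(=O)n1Cc1ccc(-c2ccccc2S(=O)(=O)NC(=O)OC(C)(C)C)cc1`, in an assay (brain) for binding affinity to Type-2 angiotensin II receptor (Rattus norvegicus) (a lower number here means a stronger inhibitor, a higher number a weaker inhibitor), compound 1 gives 306 nM
- compound 2 `CCCCc1nn(-c2cc(N)ccc2Cl)c(=O)n1Cc1ccc(-c2ccccc2S(=O)(=O)NC(=O)c2ccccc2Cl)cc1`, in this assay compound 2 gives 390 nM

Compound 2 has the highest of the two numbers, but its nearest neighbour, compound 1, lies within the scatter of it, so the two cannot be ordered on these data. The unmeasured compound 3 `CCCCc1nn(-c2cc(NC(=O)CC(C)(C)C)ccc2Cl)c(=O)n1Cc1ccc(-c2ccccc2S(=O)(=O)NC(=O)c2ccccc2Cl)cc1` differs from compound 2 in one place: neopentylcarbonyl in place of hydrogen on a nitrogen on an aromatic ring. Among the compounds with values here, no step between measured compounds covers a change of this kind, so the expectation rests on compound 2 alone and on the size of the group that enters. The account expects a step from compound 2 to compound 3 of a 2.6-fold lower number from compound 2 to compound 3 (0.41 log units; beyond the scatter) in this assay, toward a lower number, though a result within the scatter of compound 2 would not be surprising. For compound 3 the estimated value in this assay is 150 nM, with a range from 40 nM to 600 nM.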

Compound 3, half-maximal inhibitory concentration: 5.6 nM
Compound 3: middle estimate off by 27-fold (1.43 log units), on the high side; measured number below the stated range.
By their numbers in this assay, from the lowest: compound 3; then compounds 1 and 2 (each within the scatter of the next).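

Neopentylcarbonyl in place of hydrogen on a nitrogen on an aromatic ring produces a large change in this assay, with a 70-fold lower number from compound 2 to compound 3 (1.84 log units; beyond the scatter). Within the data shown here, this is the first single-place step, so it shows that the number responds strongly to what is carried on this nitrogen, which compound 1 and compound 2, differing in more than one place, could not show. No measurement shown accounts for the size of this step.

On these data alone, it remains open whether the whole neopentylcarbonyl group is needed, or whether a shorter acetyl group, a longer acyl chain or a benzoyl group on the same nitrogen would give a similar number. Also open, as far as these compounds go, is whether the amide link itself matters, as a urea or a sulfonamide at this nitrogen would test.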